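Series notes: amine substituent and growth inhibition of THP-1 cells

The compounds below may be only part of what the source reports. "The series", "measured", "known", "first", "only" and "open" are said of these compounds alone.

Of the compounds shown here, three sharing one core have been measured in an ADME assay on THP-1 cells (Homo sapiens) for cytotoxicity, read by trypan blue exclusion, with a stated time of 48 h; on this read-out higher numbers stand for weaker inhibition of growth and lower numbers for stronger inhibition of growth. Compound 1 `Cc1cc(CNCc2ccccc2)c(C)n1-c1ccc(Cl)cc1` gives 7.2 ug/mL in this assay, compound 2 `Cc1cc(CNC2CCCCC2)c(C)n1-c1ccc(Cl)cc1` gives 7.4 ug/mL, and compound 3 `Cc1cc(CNOCc2ccccc2)c(C)n1-c1ccc(Cl)cc1` gives 67 ug/mL. Compound 3 stands highest of the three: the step of a 9.3-fold higher number from compound 1 to compound 3 (0.97 log units; beyond the scatter) and the step of a 9.1-fold higher number from compound 2 to compound 3 (0.96 log units; beyond the scatter) both lie beyond the scatter, while the step of a 1.0-fold higher number from compound 1 to compound 2 (0.01 log units; within the scatter) lies within it.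

Compound 4 `Cc1ccc(CNCc2cc(C)n(-c3ccc(Cl)cc3)c2C)cc1` is the next candidate. Its change from compound 3 is 4-methylbenzyl in place of benzyloxy on an amine nitrogen. For the measured compounds named here, the steps that bear on it are those into compound 3, since benzyl and 4-methylbenzyl differ only by a methyl group on the ring: the benzyloxy group that raised the number in a 9.3-fold higher number from compound 1 to compound 3 (0.97 log units; beyond the scatter) is removed again, and the step of a 9.1-fold higher number from compound 2 to compound 3 (0.96 log units; beyond the scatter) shows the same size of change from a different neighbour. Reversing that change is therefore expected to return the number in this assay to the region of compound 1 and compound 2, with the methyl group adding only an uncertain amount.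

Compound 4 is estimated at 8 ug/mL in this assay, in a range of 4 ug/mL to 20 ug/mL, which means an expected step of an 8.4-fold lower number from compound 3 to compound 4 (0.92 log units; beyond the scatter).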

Compound 4, concentration for 50% growth inhibition: 6.1 ug/mL
Beside the measured number, compound 4's estimate is 1.3-fold (0.12 log units) above it; measured number inside the range.
By their numbers in this assay, from the lowest: compounds 4, 1 and 2 (each within the scatter of the next); then compound 3.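

Replacing benzyloxy with 4-methylbenzyl on the amine nitrogen gives an 11-fold lower number from compound 3 to compound 4 (1.04 log units; beyond the scatter) in this assay, showing directly that the high number of compound 3 does not persist when benzyloxy is exchanged for this substituted benzyl group. Adding the methyl group on an aromatic carbon gives a 1.2-fold lower number from compound 1 to compound 4 (0.07 log units; within the scatter), and exchanging cyclohexyl for 4-methylbenzyl gives a 1.2-fold lower number from compound 2 to compound 4 (0.08 log units; within the scatter); both steps lie within the scatter, so neither change can be distinguished here, and among the four compounds only compound 3 stands apart. No supporting measurement is available to explain the separation of compound 3 from the other compounds.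

The compounds shown leave open whether the large step belongs to the oxygen atom or to the benzyloxy group as a whole, a question that 2-phenylethyl on the same nitrogen could help to separate. They also leave open whether the absence of a clear methyl step extends to other groups on that aromatic ring, such as methoxy, chloro or trifluoromethyl, since a single methyl group is the only ring substituent represented on the benzyl group.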